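The compounds below may be only part of what the source reports. "The series", "measured", "known", "first", "only" and "open" are said of these compounds alone.

Working notes on the series. Of the compounds shown here, two have numbers so far. Compound 1 `COC1=C(C(=O)c2ccccc2[N+](=O)[O-])C(=O)CCC1` in an assay for inhibition of 4-hydroxyphenylpyruvate dioxygenase (Sus scrofa) (on this read-out higher numbers stand for weaker inhibition and lower numbers for stronger inhibition), gives 52000 nM. Compound 2 `O=C1CCCC(O)=C1Cc1ccccc1[N+](=O)[O-]` in this assay gives 126000 nM. On these two numbers compound 1 stands lowest, and the gap to compound 2 lies beyond the scatter of repeated measurements; beyond that pair nothing can be said of a trend.

The next compound, compound 3 `O=C1CCCC(Cl)=C1C(=O)c1ccccc1[N+](=O)[O-]`, is not yet measured in this assay. It differs from compound 1 in one place: chloro in place of methoxy on a double-bonded ring carbon, next to the ring atom that bears a large group. Within the data shown here, no step between measured compounds covers such an exchange, so the expectation rests on compound 1 alone. The expected step from compound 1 to compound 3 is a 1.3-fold lower number from compound 1 to compound 3 (0.11 log units; within the scatter), small and not beyond the scatter. Compound 3 is therefore estimated at 40000 nM, within a range of 10000 nM to 150000 nM.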

Compound 3, half-maximal inhibitory concentration: 64000 nM
Estimate against measurement, compound 3: 1.6-fold (0.20 log units) below; measured number inside the range.
By their numbers in this assay, from the lowest: compounds 1, 3 and 2 (each within the scatter of the next, the first and the last beyond it).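

In this assay, among these compounds, chloro in place of methoxy on a double-bonded ring carbon gives a 1.2-fold higher number from compound 1 to compound 3 (0.09 log units; within the scatter) and so is the first exchange that can be read at this place. Methoxy, with 2 heavy atoms and 1 hydrogen-bond acceptor, gives way here to chloro, with 1 heavy atom and 0 hydrogen-bond acceptors, and the step stays within the scatter, so on this one pair the number does not depend on which of the two groups sits here. No measurement at hand gives a reason for the size of this step.

As far as these compounds go, whether an amine, a carboxylic acid or a longer chain such as butoxy at this place would also stay within the scatter remains open. So does whether the same exchange would read alike with a methylsulfonyl group in place of the nitro group.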